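Fluoro in Place of Iodo: Expected Cell Inhibition

The source may report more compounds than this note shows. Statements on the series, on what has been measured and on what is new or still open speak of the compounds shown alone.

Measured so far:
compound 1 `CC(=O)OC(C)n1cnc2c(Cl)nc(N)nc21`: > 500000 nM
compound 2 `CC(=O)OC(C)n1cnc2c(Cl)nc(I)nc21`: 3550 nM
compound 3 `CC(=O)OC(C)n1cnc2c(N)nc(I)nc21`: > 500000 nM

Going by the values given here, in a functional assay on SW-620 cells (Homo sapiens) for inhibition (a lower number here means a stronger inhibitor, a higher number a weaker inhibitor), compound 2 gives 3550 nM, the only true number among the three measured compounds. For compound 1 the reported > 500000 nM is a limit of the assay, not a number. For compound 3 the reported > 500000 nM is likewise a limit. Both sit at the limit of > 500000 nM in this assay, at which 2 of the 3 values shown sit, so the two steps leading to and from compound 2 are large: an at least 140-fold lower number from compound 1 to compound 2 (2.14 log units; beyond the scatter), and an at least 140-fold higher number from compound 2 to compound 3 (2.14 log units; beyond the scatter).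

Compound 4 `CC(=O)OC(C)n1cnc2c(Cl)nc(F)nc21` differs from compound 2 in one place: fluoro in place of iodo on an aromatic carbon. The measured step that bears on this position is an at least 140-fold lower number from compound 1 to compound 2 (2.14 log units; beyond the scatter), where iodo in place of amino brought the compound from the limit down to a real number. Among the compounds with values here, no measured step shows how fluoro compares with iodo at this position, so the direction is taken from that one step and the size is uncertain. Compound 4 is therefore expected to be a weaker inhibitor than compound 2, with a step of an 11-fold higher number from compound 2 to compound 4 (1.05 log units; beyond the scatter). The estimate for compound 4 is 40000 nM, within a range from 5000 nM to 300000 nM.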

Compound 4, half-maximal inhibitory concentration: 8900 nM
The estimate for compound 4 lay 4.5-fold (0.65 log units) above the measured number; low and high end bracket the measured number.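

In this assay, fluoro in place of iodo gives only a modest change (a 2.5-fold higher number from compound 2 to compound 4 (0.40 log units; beyond the scatter)), so a measurable inhibition at this position is not tied to iodo alone. Fluoro in place of amino gives a large change (an at least 56-fold lower number from compound 1 to compound 4 (1.74 log units; beyond the scatter)), which means that two different halogens at this position now both give a real number where amino does not. The value of compound 1, > 500000 nM, is a limit of the assay and not a number: the limit of > 500000 nM in this assay, at which 2 of the 4 values shown sit.

The compounds shown leave open whether bromo, or a carbon group such as methyl or nitrile, would keep this inhibition at the same position. They also leave open whether a fluoro compound would lose its inhibition when amino replaces the chloro group, as the iodo compound does.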